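The source may hold more compounds than are shown below. What is called first, only, known or untested is meant among the compounds shown, and "the series" means these compounds.

In a physicochemical assay for lipophilicity, measured as octanol-water partition, at pH 7.4 (a higher number here means a more lipophilic compound, a lower number a more polar compound), compound 1 (`O=C([C@H](O)CS(=O)(=O)c1ccc2cc(Cl)ccc2c1)N1CCC(N2CCCS2(=O)=O)CC1`) gives 1.69, compound 2 (`O=C([C@H](O)CS(=O)(=O)c1ccc2cc(Cl)ccc2c1)N1CCC(N2CCCC2)CC1`) gives 1.56 and compound 3 (`O=C([C@H](O)CS(=O)(=O)c1ccc2cc(Cl)ccc2c1)N1CCC(N2CCCOC2=O)CC1`) gives 1.67, so compound 3 stands within the scatter of both others. Compound 4 (`O=C([C@H](O)CS(=O)(=O)c1ccc2cc(Cl)ccc2c1)N1CCC(N2NCCCC2=O)CC1`) carries a group of 7 heavy atoms (4 carbon, 2 nitrogen, 1 oxygen; one six-membered non-aromatic ring with 2 hetero atoms) in place of a group of 7 heavy atoms (4 carbon, 1 nitrogen, 2 oxygen; one six-membered non-aromatic ring with 2 hetero atoms), on a saturated ring carbon. Among the compounds with values here, three measured steps bear on this change, a number 0.02 log units lower from compound 1 to compound 3 (within the scatter), a number 0.11 log units higher from compound 2 to compound 3 (within the scatter) and a number 0.13 log units lower from compound 1 to compound 2 (within the scatter), and all three stay within the scatter although different groups are exchanged. None of them brings in the group of compound 4, so they serve only as analogy. Expected in this assay is therefore no change beyond the scatter, an estimated a number 0.17 log units lower from compound 3 to compound 4 (within the scatter). For compound 4 the estimated value is 1.5, with an expected range from 1.15 to 1.85.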

Compound 4, distribution coefficient: 1.85
Beside the measured number, compound 4's estimate is 0.35 log units below it, and the stated range covers the measured number.
By their numbers in this assay, from the lowest: compounds 2, 3, 1 and 4 (each within the scatter of the next).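

In this assay, the change from the group of compound 3 to one with 1 hydrogen-bond donor on this saturated ring carbon gives a number 0.18 log units higher from compound 3 to compound 4 (within the scatter). The other two steps agree, with a number 0.29 log units higher from compound 2 to compound 4 (within the scatter) and a number 0.16 log units higher from compound 1 to compound 4 (within the scatter), so all four groups shown here lie within the scatter of one another, even with a donor present. No measurement given here accounts for these numbers. From the compounds shown here alone, whether a charged group at this place, such as a primary amine or a carboxylic acid, would also stay within the scatter remains open.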